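The compounds below may be only part of what the source reports. "The series", "measured", "known", "first", "only" and "open" are said of these compounds alone.

Measured in an ADME assay on Akata cells (Homo sapiens) for cytotoxicity, with a stated time of 7 days; on this read-out higher numbers stand for lower toxicity in this test and lower numbers for higher toxicity in this test:
- compound 1 `Nc1nc(OCC(F)(F)F)c2ncn(/C=C3/CC3(CO)CO)c2n1`: > 20000 nM
- compound 2 `CN(C)c1nc(N)nc2c1ncn2/C=C1/CC1(CO)CO`: > 24000 nM
- compound 3 `CCCCCCSc1nc(N)nc2c1ncn2/C=C1/CC1(CO)CO`: > 20000 nM

None of these entries is a number, and compound 3 has only a limit, > 20000 nM. The other two compounds are limits as well, so the set offers (the limit of > 20000 nM in this assay, at which 2 of the 3 values shown sit), and (the limit of > 24000 nM in this assay, at which 1 of the 3 values shown sits).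

Compound 4 `CCCOc1nc(N)nc2c1ncn2/C=C1/CC1(CO)CO` carries propoxy in place of hexylsulfanyl on an aromatic carbon of the shared core: propoxy in place of hexylsulfanyl on an aromatic carbon.

Three measured steps change the group at this same carbon: a step that the two limits leave unreadable from compound 1 to compound 3, a step that the two limits leave unreadable from compound 2 to compound 3 and a step that the two limits leave unreadable from compound 1 to compound 2. None of them gives a size to carry over. Compound 1, with 2,2,2-trifluoroethoxy on that carbon, is the closest comparison and stands at the limit > 20000 nM. On that basis, no step beyond the usual scatter is expected in this assay, and compound 4 will probably also be reported only as a limit.

The estimated change is a step that the limit leaves unreadable from compound 3 to compound 4.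

For compound 4 the expected value is 25000 nM, with an estimated range from 12000 nM to 50000 nM.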

Compound 4, half-maximal cytotoxic concentration: > 20000 nM
Compound 4: no number, only a limit; the forecaster's own chance of this, stated with the estimate: 75%; the middle value lies beyond the limit too.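

In this assay compound 4 is reported only as a limit, > 20000 nM. For the compounds shown here, compound 1, compound 2 and compound 3 are limits as well, and no step to compound 4 can be read. The compounds shown leave open whether any group on this aromatic carbon would give a measured number.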